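The compounds below may be only part of what the source reports. "The series", "measured", "known", "first", "only" and "open" are said of these compounds alone.

Of the compounds shown here, three have so far been measured in a functional assay on a cell-free system (plasma, Homo sapiens), with a stated time of 3 min; on this read-out lower numbers stand for stronger inhibition and higher numbers for weaker inhibition. Compound 1 (`O=C(NCc1cc(Cl)ccc1-n1cnnn1)[C@@H]1C[C@H]2C[C@H]2N1C(=O)[C@H](O)c1ccccc1`) gives 680 nM and compound 2 (`O=C(NCc1cc(Cl)ccc1-n1cnnn1)[C@@H]1[C@@H]2C[C@@H]2CN1C(=O)[C@H](O)Cc1ccccc1`) gives 970 nM, two values within the usual scatter of each other. Compound 3 (`CC(C)(C)[C@@H](O)C(=O)N1NCC[C@H]1C(=O)NCc1cc(Cl)ccc1-n1cnnn1`) gives 1700 nM, a higher number than that of compound 1 and beyond the scatter from it, though within the scatter of compound 2. Compound 1 therefore stands at the low end of this small set, together with compound 2.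

Compound 4 (`O=C(NCc1cc(Cl)ccc1-n1cnnn1)[C@@H]1C[C@H]2C[C@H]2N1C(=O)[C@H](O)c1cccc(F)c1`) keeps the core of compound 1 and turns the phenyl group into 3-fluorophenyl: fluoro in place of hydrogen on an aromatic carbon. This places fluoro in place of hydrogen on an aromatic carbon, meta to a large group. Among the measured compounds shown here, no two measured compounds differ in one place alone, so the data offer no direct precedent for the size of this change. In this assay, the expectation is therefore a small move towards a lower number, most likely none beyond the scatter, starting from compound 1 at 680 nM. The expected change is a 1.3-fold lower number from compound 1 to compound 4 (0.12 log units; within the scatter). For compound 4 the estimated value is 520 nM, with an expected range from 200 nM to 1300 nM.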

Compound 4, half-maximal inhibitory concentration: 1100 nM
Compound 4: the middle estimate sits 2.1-fold (0.33 log units) below what was measured; the measured number falls inside the stated range.
By their numbers in this assay, from the lowest: compounds 1, 2, 4 and 3 (each within the scatter of the next, the first and the last beyond it).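

This is the first pair among the compounds shown that differs in one place alone, so it gives the first direct reading of a change on the phenyl group of the core of compound 1. In this assay, fluoro in place of hydrogen on an aromatic carbon, meta to a large group, gives a 1.6-fold higher number from compound 1 to compound 4 (0.21 log units; within the scatter). This single step therefore shows that phenyl to 3-fluorophenyl leaves the read-out within the usual scatter, so that at this place one fluoro cannot be told apart from hydrogen, and the compounds shown offer no evidence that would bear on the reason for this result.

From the compounds shown here alone, what remains open is whether this holds only for so small a group, since a single fluoro says nothing about how a chloro, a methoxy, an amine or a carboxylic acid would read at the same place on this aromatic ring. Going by these compounds, it also stays open whether phenyl to 3-fluorophenyl would read the same on another core, and whether a larger group here would bring a step that goes beyond the scatter in either direction.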